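A few compounds are considered here, and "the series" means these few. Any claim that something is new, unique, unknown or untested is made for them only; others in the source may bear on it.

Measured in a functional assay on Huh-7 cells (Homo sapiens) for inhibition, read by MTT assay, with a stated time of 72 h; on this read-out lower numbers stand for stronger inhibition and higher numbers for weaker inhibition:
Compound 1 `CNC(=O)CCCCCCCn1nc(-c2cnc3[nH]ccc3c2)c2c(N)ncnc21`: 23500 nM
Compound 2 `Nc1ncnc2c1c(-c1cnc3[nH]ccc3c1)nn2CCCCCCCCC(=O)NO`: 7380 nM
Compound 3 `Nc1ncnc2c1c(-c1cnc3[nH]ccc3c1)nn2CCCCCCC(=O)NO`: 50900 nM

Compound 3 gives the highest number of the three and is the weakest inhibitor of the set. The measurements show a 2.2-fold higher number from compound 1 to compound 3 (0.34 log units; beyond the scatter) and a 6.9-fold higher number from compound 2 to compound 3 (0.84 log units; beyond the scatter).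

Compound 4 `Nc1nc2cc(-c3nn(CCCCCCC(=O)NO)c4ncnc(N)c34)ccc2o1` keeps the chain of compound 3 and differs only in the group on an aromatic carbon of the core, where 2-amino-1,3-benzoxazol-5-yl enters: a group of 10 heavy atoms (7 carbon, 2 nitrogen, 1 oxygen; one five-membered aromatic ring with 2 hetero atoms, one six-membered aromatic ring of carbon only) in place of a group of 9 heavy atoms (7 carbon, 2 nitrogen; one five-membered aromatic ring with 1 hetero atom, one six-membered aromatic ring with 1 hetero atom), on an aromatic carbon. Among the measured compounds shown here, no measured step touches this group. The two steps above and a 3.2-fold lower number from compound 1 to compound 2 (0.50 log units; beyond the scatter) all change the chain or its end, so they bear on the change only indirectly, by showing that single changes in this series have so far moved the number modestly. They give no direction for this replacement. A modest step toward a lower number is nevertheless expected, on weak grounds: compound 3 stands at the top of the series, and compound 2, at 7380 nM, shows that lower numbers are reachable. The expected change is a 2.5-fold lower number from compound 3 to compound 4 (0.41 log units; beyond the scatter). For compound 4 the estimated value is 20000 nM, with an expected range from 4000 nM to 70000 nM.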

Compound 4, half-maximal inhibitory concentration: 5710 nM
Beside the measured number, compound 4's estimate is 3.5-fold (0.54 log units) above it; the measured number falls inside the stated range.
By their numbers in this assay, from the lowest: compounds 4 and 2 (each within the scatter of the next); then compound 1; then compound 3.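

In this assay, the group on the aromatic carbon of the core turns out to be a second place where the number can be moved, as every earlier step changed only the chain or its end. With the chain of compound 3 held fixed, putting 2-amino-1,3-benzoxazol-5-yl in place of the earlier group gives an 8.9-fold lower number from compound 3 to compound 4 (0.95 log units; beyond the scatter) and lies beyond the scatter, so this single ring-system change on the aromatic carbon is of a size similar to the largest chain step, a 6.9-fold higher number from compound 2 to compound 3 (0.84 log units; beyond the scatter) and not a silent exchange. Nothing in the data shown accounts for why this replacement lowers the number.

Still open is whether 2-amino-1,3-benzoxazol-5-yl would give a similar step on the longer chain of compound 2 or with the methylcarbamoyl end of compound 1, since the compounds shown place it on one chain only. Also open is which part of the entering group goes with the step: the compounds shown do not separate the amine on the five-membered ring from the ring oxygen, and a benzoxazol-5-yl group without the amine would bear on that.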